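Methyl to Nitro on the Sulfonyl Ring, Second Core

The compounds below may be only part of what the source reports. "The series", "measured", "known", "first", "only" and "open" are said of these compounds alone.

Of the compounds shown here, three have been measured in a functional assay for inhibition, read by spectrophotometry, with a stated time of 20 min, tested at 4 mg/mL; on this read-out lower numbers stand for a weaker effect and higher numbers for a stronger effect at the one concentration tested. Compound 1 `CC(=O)c1ccc(NC(=O)CN(C(=O)c2ccccc2)S(=O)(=O)c2ccc(C)cc2)cc1` gives 18.5% in this assay. Compound 3 `CC(=O)c1ccc(NC(=O)CN(C(=O)c2ccccc2)S(=O)(=O)c2ccc([N+](=O)[O-])cc2)cc1` differs from compound 1 in one place only, (nitro in place of methyl on an aromatic carbon), and in this assay compound 3 gives 20.7%. The step of a number 2.2 percentage points higher from compound 1 to compound 3 (within the scatter) is therefore small, and the two numbers cannot be told apart with confidence.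

Compound 2 `CC(=O)c1ccc(NC(=O)C2CC(O)CN2S(=O)(=O)c2ccc(C)cc2)cc1` is built on a second core; the difference between the two cores is not broken down here. In this assay compound 2 gives 12.9%. This number lies within the scatter of both compound 1 and compound 3, so no order among the three measured compounds can be read from these figures.

Compound 4 `CC(=O)c1ccc(NC(=O)C2CC(O)CN2S(=O)(=O)c2ccc([N+](=O)[O-])cc2)cc1` has not yet been measured. It is made from compound 2 by the same change that leads from compound 1 to compound 3, (nitro in place of methyl on an aromatic carbon), and the surroundings of the change are the same in both pairs. Resting on the one measured example of this change, the step of a number 2.2 percentage points higher from compound 1 to compound 3 (within the scatter), the expected step is a number 2.1 percentage points higher from compound 2 to compound 4 (within the scatter), because a number 2.2 percentage points higher from compound 1 to compound 3 (within the scatter) stayed within the scatter. In this assay compound 4 is thus estimated at 15%, most likely between 5% and 26%.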

Compound 4, a percentage reported as inhibition, at one concentration (the size of the read-out at that concentration, not a potency): 60.1%
Beside the measured number, compound 4's estimate is 45.1 percentage points below it, and the stated range ends below it.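

Replacing 4-methylphenyl with 4-nitrophenyl on the core of compound 2 gives a number 47.2 percentage points higher from compound 2 to compound 4 (beyond the scatter) in this assay. So this change cannot simply be carried from one core to the other with its size unchanged, and a small step on one core is a poor guide to the step on the other: the same change on two cores in this assay, a number 2.2 percentage points higher (within the scatter) from compound 1 to compound 3 and a number 47.2 percentage points higher (beyond the scatter) from compound 2 to compound 4, 45 percentage points apart, beyond the scatter of two such steps

For the compounds shown here, this does not show which feature of the two cores goes with the difference, nor how the change would behave on a further core, since each core offers only a single pair, and the numbers come from one concentration, so they say nothing about potency.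

The compounds shown leave open whether the large step belongs to nitro alone, or whether another group in the same place on the core of compound 2, such as a nitrile, a carboxylic acid or an amine, would give a similar result. They also leave open whether the hydroxyl group on the core of compound 2 has any part in the step, a question that a close relative of compound 4 carrying a methoxy group there could begin to address.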